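Swapping imidazole substituents on a melanocortin-4 ligand

The source may report more compounds than this note shows. Statements on the series, on what has been measured and on what is new or still open speak of the compounds shown alone.

Measured so far in an assay on isolated protein for binding affinity to Melanocortin receptor 4 (Homo sapiens); a higher number here means a weaker inhibitor, a lower number a stronger inhibitor:
- compound 1 `COc1ccc(Br)cc1CCc1ccccc1-c1ncc(C)n1C`: 180 nM
- compound 2 `CCc1cn(C)c(-c2ccccc2CCc2cc(Br)ccc2OC)n1`: 690 nM

Within the data shown here, compound 2 has the highest number of the two, and the only step that links it to a measured neighbour runs the other way: a 3.8-fold higher number from compound 1 to compound 2 (0.58 log units; beyond the scatter).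

Compound 3 `COc1ccc(Br)cc1CCc1ccccc1-c1nc(C)c(C)n1C` is not yet measured. The change from compound 2 is 1,4,5-trimethyl-1H-imidazol-2-yl in place of 4-ethyl-1-methyl-1H-imidazol-2-yl on an aromatic carbon. Among the measured compounds shown here, this change reinstates the methyl that compound 1 carries on the imidazole ring and shortens the ethyl of compound 2 to a methyl, so the only step that bears on it is that from compound 1 to compound 2, a modest one beyond the scatter. Compound 3 is therefore expected to land between the two measured values, somewhat nearer to compound 1, so that a 2.3-fold lower number from compound 2 to compound 3 (0.36 log units; beyond the scatter) is the expected step. The estimate for compound 3 in this assay is 300 nM, with a range from 100 nM to 900 nM.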

Compound 3, inhibition constant: 140 nM
The estimate for compound 3 lay 2.1-fold (0.33 log units) above the measured number, within the range that was stated.
By their numbers in this assay, from the lowest: compounds 3 and 1 (each within the scatter of the next); then compound 2.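

In this assay, replacing 4-ethyl-1-methyl-1H-imidazol-2-yl with 1,4,5-trimethyl-1H-imidazol-2-yl restores binding (a 4.9-fold lower number from compound 2 to compound 3 (0.69 log units; beyond the scatter)), a step beyond the scatter. Adding one methyl to the imidazole of compound 1 makes no readable difference (a 1.3-fold lower number from compound 1 to compound 3 (0.11 log units; within the scatter)), so this ring carbon accepts a methyl, and a substituent there does not in itself bring the weaker binding of compound 2. No measurement offered here explains these numbers.

Compound 2 differs from compound 3 in two ways at once, so the ethyl and the absent ring methyl cannot be told apart, and a 4-ethyl-1,5-dimethyl-1H-imidazol-2-yl group would separate them. On these data alone, whether a propyl chain or an amine would be accepted on this ring also stays open.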